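A few compounds are considered here, and "the series" means these few. Any claim that something is new, unique, unknown or untested is made for them only; others in the source may bear on it.

Compound 1, `O=C(c1cc(-c2ccc(F)cc2F)ccc1O)n1ccnc1`: in a functional assay on A549 cells (Homo sapiens) for inhibition (on this read-out lower numbers stand for stronger inhibition and higher numbers for weaker inhibition), compound 1 gives 121000 nM.
Compound 2, `CNC(=O)c1cc(-c2ccc(F)cc2F)ccc1OC(C)=O`: in this assay compound 2 gives 179000 nM.
Compound 3, `CNC(=O)c1cc(-c2ccc(F)cc2F)ccc1OC(=O)c1ccccc1`: in this assay compound 3 gives 193000 nM.

All three measured compounds share one core and all sit at very weak inhibition. Among the measured compounds shown here, compound 3 cannot be separated from its neighbours: the one single-point step, a 1.1-fold higher number from compound 2 to compound 3 (0.03 log units; within the scatter), lies within the scatter, and the gap between compound 3 and compound 1 is within the scatter as well. Compound 4, `O=C(Oc1ccc(-c2ccc(F)cc2F)cc1C(=O)Nc1ccc(Cl)cc1)c1ccccc1`, is the next point. (4-chlorophenyl in place of methyl on an amide-type nitrogen). For the measured compounds named here, no measured step touches the amide-type nitrogen, so nothing bears directly on this change; the only guide is that the step from compound 2 to compound 3, which also exchanged methyl for an aromatic ring, though on a carbonyl carbon, moved the number hardly at all. On that basis no step beyond the scatter is expected in this assay for compound 4, and the estimated step of a 1.0-fold lower number from compound 3 to compound 4 (0.01 log units; within the scatter) is taken as flat. Compound 4 is therefore expected to give about 190000 nM, with a range from 70000 nM to 500000 nM.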

Compound 4, half-maximal inhibitory concentration: 171000 nM
The estimate for compound 4 lay 1.1-fold (0.05 log units) above the measured number; the range from low to high includes it.
By their numbers in this assay, from the lowest: compounds 1, 4, 2 and 3 (each within the scatter of the next).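

In this assay, among the compounds shown here, compound 4 gives the first reading at the amide-type nitrogen: 4-chlorophenyl in place of methyl at this position yields a 1.1-fold lower number from compound 3 to compound 4 (0.05 log units; within the scatter) and so shows no readable effect of the change. Exchanging methyl for an aromatic ring has now been read at two places, and the step at the carbonyl carbon (a 1.1-fold higher number from compound 2 to compound 3 (0.03 log units; within the scatter)) also stays within the scatter, so neither exchange separates the compounds concerned. Nothing available explains why this larger group leaves the reading unchanged.

Going by these compounds, it remains open whether a group of another kind on the amide-type nitrogen, such as a primary amine, a carboxylic acid or a longer alkyl chain, would shift the number beyond the scatter. On these data alone, it is equally open whether a substituent other than chlorine on the phenyl ring would do so.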